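Replacing a terminal methyl with hydroxy on the side chain

This account rests on a few compounds, and the source may have more. Where it says the series, first, only, none or still open, it means among the compounds named here.

Measured so far:
compound 1, `C=CC[C@@H]1C[C@@H](c2ccc(Cl)c(Cl)c2)[C@H](NC(=O)c2cc(-c3c(Cl)cnn3C)c(Cl)o2)CN1`, gives 12.4 nM in an assay for inhibition of RAC-alpha serine/threonine-protein kinase (Homo sapiens), read by HTRF, with a stated time of 1 h; a lower number here means a stronger inhibitor, a higher number a weaker inhibitor
compound 2, `CCC[C@@H]1C[C@@H](c2ccc(Cl)c(Cl)c2)[C@H](NC(=O)c2cc(-c3c(Cl)cnn3C)c(Cl)o2)CN1`, gives 10.4 nM in this assay

Within the data shown here, compound 2 and compound 1 cannot be told apart: the one measured step, a 1.2-fold lower number from compound 1 to compound 2 (0.08 log units; within the scatter), lies within the scatter. Compound 3, `Cn1ncc(Cl)c1-c1cc(C(=O)N[C@@H]2CN[C@H](CCO)C[C@H]2c2ccc(Cl)c(Cl)c2)oc1Cl`, carries hydroxy in place of methyl on a saturated chain carbon, two bonds along the chain from a saturated ring carbon. Among the measured compounds shown here, that measured step concerns a different change on the same chain and was small, so it says little about a hydroxy entering there; no measured compound carries one. The expected step from compound 2 to compound 3 in this assay is therefore a 1.4-fold higher number from compound 2 to compound 3 (0.16 log units; within the scatter), a guess with a wide range. Compound 3 is estimated to give 15 nM, expected between 5 nM and 45 nM.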

Compound 3, half-maximal inhibitory concentration: 2.74 nM
The estimate for compound 3 lay 5.5-fold (0.74 log units) above the measured number; measured number below the stated range.
By their numbers in this assay, from the lowest: compound 3; then compounds 2 and 1 (each within the scatter of the next).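

On this side chain, the earlier exchange of vinyl for ethyl moved nothing beyond the scatter, but hydroxy in place of methyl does in this assay (a 3.8-fold lower number from compound 2 to compound 3 (0.58 log units; beyond the scatter)). Hydroxymethyl in place of vinyl at the same place gives a step of similar standing (a 4.5-fold lower number from compound 1 to compound 3 (0.66 log units; beyond the scatter)), so the number here responds to what the chain carries at its end. Nothing available explains this gain. Still open, going by these compounds, is whether an amine or a carboxylic acid at the end of this chain would serve as well as hydroxy. Also open, on these data alone, is whether a longer chain ending in hydroxy would keep the gain.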